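The source may hold more compounds than are shown below. What is called first, only, known or untested is meant among the compounds shown, and "the series" means these compounds.

Compounds measured so far:
Compound 1 `Nc1nc(Cl)c(-c2nc3ccc(F)cc3s2)c(N[C@@H]2C[C@H](CO)[C@@H](O)[C@H]2O)n1` gives > 25000 nM, which is a limit of the assay rather than a number.
Compound 2 `Cc1nc(NCC2CCC2)nc(N[C@@H]2C[C@H](CO)[C@@H](O)[C@H]2O)c1-c1nc2ccccc2s1` gives > 25000 nM, again a limit of the assay and not a number.

Both results come from an ADME assay on cells (Homo sapiens) for cytotoxicity, read by polymerase chain reaction, with a stated time of 3 days; a higher number here means that more compound is tolerated, a lower number that less compound is tolerated. Going by the values given here, compound 2 therefore stands at the upper edge of what this assay reports, and so does the only other value shown, since (the limit of > 25000 nM in this assay, at which 2 of the 2 values shown sit). Among the compounds with values here, no step between two measured compounds that differ in a single place is available, so nothing yet shows how any one change moves a reading in this assay.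

Compound 3 `Cc1nc(Nc2nccs2)nc(N[C@@H]2C[C@H](CO)[C@@H](O)[C@H]2O)c1-c1nc2ccccc2s1` is the next compound, not yet measured. It differs from compound 2 in one place: 1,3-thiazol-2-yl in place of cyclobutylmethyl on a nitrogen on an aromatic ring. Within the data shown here, with both measured compounds sitting at the limit, there is no measured step on which to base a direction; the step from compound 2 to compound 3 is expected to be an at least 1.3-fold lower number from compound 2 to compound 3 (0.14 log units; that floor lies within the scatter), that is, nothing clearly beyond the scatter, though a reading below the limit cannot be ruled out. Compound 3 is accordingly estimated at 18000 nM, within a range from 4000 nM to 25000 nM.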

Compound 3, half-maximal cytotoxic concentration: 15000 nM
The estimate for compound 3 lay 1.2-fold (0.08 log units) above the measured number, and the stated range covers the measured number.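

Of the compounds shown, compound 3 alone gives a number in this assay rather than a limit, so the substituent on this nitrogen on an aromatic ring is the first place tied to a reading inside the range. The change from (cyclobutylmethyl)amino to (1,3-thiazol-2-yl)amino keeps the count of heavy atoms in the group the same, brings in a five-membered aromatic ring with 2 hetero atoms and 2 hydrogen-bond acceptors, and gives an at least 1.6-fold lower number from compound 2 to compound 3 (0.22 log units; that floor lies within the scatter). On these data alone, its true size stays unknown, and only this floor can be stated, because compound 2 sits at a limit of the assay and not at a number: the limit of > 25000 nM in this assay, at which 2 of the 3 values shown sit.

As far as these compounds go, it remains open whether the reading follows from the aromatic ring, from its nitrogen or sulfur, or from the loss of cyclobutylmethyl, since this single step cannot separate them. From the compounds shown here alone, what a phenyl ring, a pyridine ring or a longer alkyl chain on this nitrogen would give in this assay is also open, as is whether the same change would act alike on a core carrying an amine and a chlorine, as in compound 1.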